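A few compounds are considered here, and "the series" means these few. Any claim that something is new, unique, unknown or untested is made for them only; others in the source may bear on it.

Of the compounds shown here, three of a shared core have been measured in an in vitro assay on HEK385-7 cells for displacement of a labelled ligand from prostaglandin D2 receptor 2 (Homo sapiens); a lower number here means a stronger inhibitor, a higher number a weaker inhibitor. Compound 1 `O=C(O)Cc1sc(C(c2ccc(F)cc2)c2ccc(F)cc2)nc1-c1ccccc1` gives 16 nM, the lowest number of the three. Compound 3 `O=C(O)Cc1sc(C(c2ccccc2)c2ccccn2)nc1-c1ccc(Cl)cc1` gives 810 nM in this assay, and compound 2 `O=C(O)Cc1sc(C(c2ccccc2)c2ccccc2)nc1-c1ccc(C(F)(F)F)cc1` gives 1100 nM, so both of these stand well above compound 1, and the gaps from compound 1 to each of them lie beyond the usual scatter. These three differ from one another in several places at once, so no single change can be read off from them.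

Compound 4 `Cc1cc(-c2nc(C(c3ccc(F)cc3)c3ccc(F)cc3)sc2CC(=O)O)ccn1` is the next compound to be tested in this assay. It differs from compound 1 in one place: 2-methylpyridin-4-yl in place of phenyl on an aromatic carbon. Among the compounds with values here, nothing among the measured compounds tells how this exchange acts on the numbers. The rest of compound 1 is kept, so a small step is expected from compound 1 to compound 4, estimated as a 1.9-fold higher number from compound 1 to compound 4 (0.27 log units; within the scatter), probably toward a somewhat higher number but perhaps none beyond the scatter. Compound 4 is therefore expected to give about 30 nM in this assay, within a range of 8 nM to 110 nM.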

Compound 4, half-maximal inhibitory concentration: 3.1 nM
For compound 4 the middle estimate is 9.7-fold (0.99 log units) above the measured one; measured number outside the range, below it.
By their numbers in this assay, from the lowest: compound 4; then compound 1; then compounds 3 and 2 (each within the scatter of the next).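

At the aromatic carbon next to the ring nitrogen and next to the ring atom that bears a carboxymethyl group, putting 2-methylpyridin-4-yl in place of phenyl gives a 5.2-fold lower number from compound 1 to compound 4 (0.71 log units; beyond the scatter) in this assay. Within the data shown here, this is the first single change that can be read at this position, and it shows that the position takes a ring with one hetero atom and one hydrogen-bond acceptor with a move to a lower number rather than a higher one. No measurement at hand gives a reason for this step.

The exchange brings the ring nitrogen and the methyl group in together, so the compounds shown do not tell their shares apart; a pyridine ring without the methyl, or a methylphenyl group, would separate them. Also open, as far as these compounds go, is whether a larger group such as ethyl or methoxy in place of that methyl keeps the lower number.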